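A few compounds are considered here, and "the series" means these few. Any claim that something is new, unique, unknown or untested is made for them only; others in the source may bear on it.

Compounds measured so far:
compound 1 `CCC1=C(O)c2c(oc(-c3ccc(CC(C)C)cc3)cc2=O)C(CC)(CC)C1=O` — 17.4 uM
compound 2 `CCC1=C(O)c2c(oc(-c3ccc(COC)cc3)cc2=O)C(CC)(CC)C1=O` — 3.4 uM
compound 3 `CCC1=C(O)c2c(oc(-c3cc(OC)c(OC)c(OC)c3)cc2=O)C(CC)(CC)C1=O` — 5.6 uM

In a functional assay on KBVIN cells (Homo sapiens) for antiproliferative activity, read by sulforhodamine B assay, with a stated time of 3 days (a lower number here means that less compound is needed, a higher number that more compound is needed for the effect), compound 2 gives the lowest of the three numbers; compound 3 sits within the scatter of it, while compound 1 lies beyond it. The unmeasured compound 4 `CCC1=C(O)c2c(oc(-c3cc(C)ccc3C)cc2=O)C(CC)(CC)C1=O` changes the aryl group of compound 2: 2,5-dimethylphenyl in place of 4-(methoxymethyl)phenyl on an aromatic carbon. For the measured compounds named here, the one measured step that bears on this, the exchange on the same aryl group, gave a 5.1-fold lower number from compound 1 to compound 2 (0.71 log units; beyond the scatter). Reading it in reverse, replacing a group holding a hydrogen-bond acceptor with one holding none, a step toward a higher number in this assay is expected for compound 4, of size a 2.9-fold higher number from compound 2 to compound 4 (0.47 log units; beyond the scatter). Compound 4 is therefore estimated at 10 uM, in the range 4 uM to 30 uM.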

Compound 4, concentration for half-maximal effect: 3.41 uM
The estimate for compound 4 lay 2.9-fold (0.47 log units) above the measured number, outside the stated range (below it).
By their numbers in this assay, from the lowest: compounds 2, 4 and 3 (each within the scatter of the next); then compound 1.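

In this assay, the exchange of 4-(methoxymethyl)phenyl for 2,5-dimethylphenyl gave a 1.0-fold higher number from compound 2 to compound 4 (0.00 log units; within the scatter), so a hydrogen-bond acceptor in this aryl group is not needed for a number this low on the shared core. The aryl group of compound 1 also holds none, yet compound 1 gives 17.4 uM while compound 4 gives 3.41 uM, so the earlier step cannot be read as an effect of the acceptor alone. Nothing available explains this result. From the compounds shown here alone, whether either methyl group of compound 4 matters on its own remains open, as does how an amine or a carboxylic acid on this aryl group would read.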